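The compounds below may be only part of what the source reports. "The series", "measured", "known", "first", "only" and "open" are said of these compounds alone.

In a functional assay on HGC-27 cells (Homo sapiens) for antiproliferative activity, read by MTT assay, with stated times of 72 h and 4 h (on this read-out lower numbers stand for stronger inhibition and higher numbers for weaker inhibition), compound 1 `COc1ncc(-c2cc3c(N4CC5CCCC5C4)ncnc3s2)cc1NS(=O)(=O)c1ccc(F)cc1F` gives 1900 nM, while compound 2 `COc1ncc(-c2nc3c(N4CC(C)OC(C)C4)ncnc3s2)cc1NS(=O)(=O)c1ccc(F)cc1F` gives 270 nM, the lower of the two numbers and a gap beyond the usual scatter. Compound 3 `COc1ncc(-c2nc3c(N4CCCC4)ncnc3s2)cc1NS(=O)(=O)c1ccc(F)cc1F` differs from compound 2 in one place: pyrrolidin-1-yl in place of 2,6-dimethylmorpholin-4-yl on an aromatic carbon, with pyrrolidin-1-yl in place of 2,6-dimethylmorpholin-4-yl on an aromatic carbon. For the measured compounds named here, no measured pair of compounds isolates this change, so the expectation is loose. A modest move towards weaker inhibition in this assay is expected, an estimated step of a 1.7-fold higher number from compound 2 to compound 3 (0.22 log units; within the scatter). For compound 3 the estimated value is 450 nM, with an expected range of 130 nM to 1500 nM.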

Compound 3, half-maximal inhibitory concentration: 1200 nM
Compound 3: the middle estimate sits 2.7-fold (0.43 log units) below what was measured; the measured number falls inside the stated range.
By their numbers in this assay, from the lowest: compound 2; then compounds 3 and 1 (each within the scatter of the next).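

In this assay, placing pyrrolidin-1-yl instead of 2,6-dimethylmorpholin-4-yl on this aromatic carbon gives a 4.4-fold higher number from compound 2 to compound 3 (0.65 log units; beyond the scatter), so the number responds to the group at this position. This single swap removes the ring oxygen and both methyl groups together, so the step cannot be divided among them. No measured information here explains the step.

On these data alone, it remains open whether a plain morpholin-4-yl or a piperidin-1-yl at this carbon would give a number closer to that of compound 2 or compound 3.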